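Inverting one stereocentre: compound 3 to compound 4

The compounds below may be only part of what the source reports. "The series", "measured", "known", "first", "only" and "open" are said of these compounds alone.

- Compound 1 `CC1=NN(c2ccccc2)C(=O)[C@]12C(=O)C=CC[C@H]2c1ccc(C)cc1`: 5720 nM
- Compound 2 `CC1=NN(c2ccccc2)C(=O)[C@@]12C(=O)C=CC[C@H]2c1ccc(C)cc1`: 8300 nM
- Compound 3 `CC1=NN(c2ccccc2)C(=O)[C@]12C(=O)C=CC[C@H]2c1cccc(C)c1`: 10300 nM
- Compound 4 `CC1=NN(c2ccccc2)C(=O)[C@@]12C(=O)C=CC[C@H]2c1cccc(C)c1`: not yet measured

All values come from a functional assay on MDA-MB-231 cells (Homo sapiens) for inhibition, read by MTT assay, with a stated time of 72 h; on this read-out higher numbers stand for weaker inhibition and lower numbers for stronger inhibition. The three measured numbers do not separate. With 3-methylphenyl in place of 4-methylphenyl on a saturated ring carbon, the result is a 1.8-fold higher number from compound 1 to compound 3 (0.26 log units; within the scatter). The values of compound 2 and compound 3 also lie within the usual scatter of each other.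

The open step is the two compounds have the same atoms and bonds and differ only in configuration as drawn: 1 of 2 stereo elements differ; a stereocentre at a saturated ring carbon is drawn S in compound 3 and R in compound 4: a stereocentre at a saturated ring carbon is drawn S in compound 3 and R in compound 4. The same inversion has been measured once, in the 4-methylphenyl pair, where the only structural basis for any difference is the fact that compounds 1 and 2 differ only in the configuration as drawn. This single pair is the whole precedent, and it may not carry over to the 3-methylphenyl pair.

Because of a 1.5-fold higher number from compound 1 to compound 2 (0.16 log units; within the scatter) no step beyond the scatter is expected here, with at most a slight lean toward a higher number. The expected change is a 1.1-fold higher number from compound 3 to compound 4 (0.05 log units; within the scatter). In this assay the estimated value for compound 4 is 11500 nM, with an expected range from 5500 nM to 24000 nM.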

Compound 4, half-maximal inhibitory concentration: 6610 nM
For compound 4 the middle estimate is 1.7-fold (0.24 log units) above the measured one, and the stated range covers the measured number.
By their numbers in this assay, from the lowest: compounds 1, 4, 2 and 3 (each within the scatter of the next).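

Inversion of this stereocentre can now be read in two pairs, and neither step leaves the scatter: a 1.5-fold higher number from compound 1 to compound 2 (0.16 log units; within the scatter) in the 4-methylphenyl pair and a 1.6-fold lower number from compound 3 to compound 4 (0.19 log units; within the scatter) in the 3-methylphenyl pair, so neither pair gives a preference for one configuration as drawn, and the only structural difference within the second pair is this: the fact that compounds 3 and 4 differ only in the configuration as drawn. The swap of 4-methylphenyl for 3-methylphenyl can also be read a second time, giving a 1.3-fold lower number from compound 2 to compound 4 (0.10 log units; within the scatter), so moving the methyl shows no separable effect in this assay on either stereo form. The two readings of that swap also agree within the scatter: the same change on two cores in this assay, a 1.8-fold higher number (0.26 log units; within the scatter) from compound 1 to compound 3 and a 1.3-fold lower number (0.10 log units; within the scatter) from compound 2 to compound 4, 2.3-fold (0.35 log units) apart, within the scatter of two such steps.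

The compounds shown vary only the place of one methyl and the configuration at one stereocentre, so whether any change on this phenyl can separate from the scatter remains open, for example a carboxylic acid, a dimethylamino group or a longer alkyl chain in place of the methyl. The other stereocentre is drawn alike in all four compounds, which leaves the effect of inverting it open as well.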